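The source may hold more compounds than are shown below. What is called first, only, known or untested is meant among the compounds shown, and "the series" means these compounds.

In a functional assay on CHO cells for positive allosteric modulation of muscarinic acetylcholine receptor M5 (Homo sapiens), read by calcium flux (a higher number here means a larger maximal response, a lower number a smaller maximal response), three compounds have been measured:

Compound 1 `CCN(Cc1ccccc1)C(=O)C1CCN(S(=O)(=O)c2cccc(OC)c2)CC1` gives 77%.
Compound 2 `CCN(Cc1ccccc1)C(=O)C1CCN(S(=O)(=O)c2ccc3cccnc3c2)CC1` gives 66%.
Compound 3 `CCN(Cc1ccccc1)C(=O)C1CCN(S(=O)(=O)c2ccc3[nH]ncc3c2)CC1` gives 86%.

Compound 3 stands highest of the three numbers, though the gap a number 9 percentage points higher from compound 1 to compound 3 (within the scatter) is within the scatter, while the gap a number 20 percentage points higher from compound 2 to compound 3 (beyond the scatter) is beyond it. Compound 4 `CCN(Cc1ccccc1)C(=O)C1CCN(S(=O)(=O)c2ccc3cn[nH]c3c2)CC1` differs from compound 3 by 1H-indazol-6-yl in place of 1H-indazol-5-yl on a sulfonyl sulfur. Among the measured compounds shown here, no measured step swaps one arrangement of the same atoms for another; the steps that bear on this position, a number 11 percentage points lower from compound 1 to compound 2 (beyond the scatter) and a number 9 percentage points higher from compound 1 to compound 3 (within the scatter) and a number 20 percentage points higher from compound 2 to compound 3 (beyond the scatter), were all modest or within the scatter. A change of no more than the scatter is therefore expected for compound 4, namely a number 6 percentage points lower from compound 3 to compound 4 (within the scatter). For compound 4 the estimated largest response is 80%, expected to lie between 65% and 95%.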

Compound 4, largest response reached (reported as percent of maximum), in percent of the reference or control that the assay uses: 86%
Beside the measured number, compound 4's estimate is 6 percentage points below it; measured number inside the range.
By their numbers in this assay, from the lowest: compound 2; then compounds 1, 3 and 4 (each within the scatter of the next).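

In this assay, among the compounds shown here, the swap of 1H-indazol-5-yl for 1H-indazol-6-yl on the sulfonyl sulfur gives no change at the digits printed from compound 3 to compound 4 (within the scatter) and is the only step here that rearranges the same atoms, so at this position the two attachments of the indazole read alike. The 1H-indazol-6-yl group also keeps the pattern of its isomer, with a number 20 percentage points higher from compound 2 to compound 4 (beyond the scatter) and a number 9 percentage points higher from compound 1 to compound 4 (within the scatter) as its steps from the other two groups. Nothing at hand explains this match. On these data alone, whether an indole or a benzimidazole on the sulfonyl sulfur would read the same stays open, as does any replacement of the benzyl group on the amide.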